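The compounds below may be only part of what the source reports. "The series", "measured", "known", "first", "only" and "open" are said of these compounds alone.

Of the compounds shown here, two have been measured so far in a functional assay on Bel-7402 cells (Homo sapiens) for inhibition, read by MTT assay, with a stated time of 24 h, tested at 100 ug/mL; on this read-out higher numbers stand for more inhibition of growth at the one concentration tested and lower numbers for less inhibition of growth. Compound 1 `CC(=O)SCCC(CCCCC(=O)O)SC(C)=O` gives 8.35% and compound 2 `O=C(CCCCC1CCSS1)NO` gives 12.5%. These values lie within the usual scatter of each other, so the two compounds cannot be ranked. Compound 3 `CC(=O)SCCC(CCCCC(=O)Nc1ccc(Cl)cc1)SC(C)=O` keeps the core of compound 1 and differs in one place, on a carbonyl carbon: (4-chlorophenyl)amino in place of hydroxy on a carbonyl carbon. In words, (4-chlorophenyl)amino stands in place of hydroxy. For the measured compounds named here, no measured pair shows what such a swap does, so any expectation here is loose. With compound 1 at 8.35%, the read-out has far more room to rise than to fall, so a modest rise is expected. The estimated shift is a number 11.7 percentage points higher from compound 1 to compound 3 (beyond the scatter), which may barely clear the scatter. For compound 3 the expected value is 20%, with an estimated range of 8% to 45%.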

Compound 3, percent growth inhibition at one concentration: 45.5%
Estimate against measurement, compound 3: 25.5 percentage points below; the whole stated range lies below it.
By their numbers in this assay, from the lowest: compounds 1 and 2 (each within the scatter of the next); then compound 3.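

In this assay, (4-chlorophenyl)amino in place of hydroxy on a carbonyl carbon gives a number 37.2 percentage points higher from compound 1 to compound 3 (beyond the scatter). For the compounds shown here, this is the first step measured at this position, and it shows that a change here, with the rest of the molecule kept, can move growth inhibition by much more than the scatter. It also shows that the hydroxy of the carboxylic acid in compound 1 is not needed for inhibition at the one concentration tested, although nothing available here explains the rise.

This single step brings in the amide nitrogen and the chlorine-bearing aromatic ring together, so it cannot show which of them matters. A plain phenylamino group, without the chlorine, or a small methylamino group on the same carbonyl carbon would begin to separate these two parts.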